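The compounds below may be only part of what the source reports. "The series", "measured", "known", "first", "only" and "open" are said of these compounds alone.

The series shares the core of compound 1 `COc1ccc(/C=N/NC(=O)Nc2ccc(Oc3ccnc4cc(OCCCN5CCCCC5)c(OC)cc34)c(F)c2)cc1`, which in a functional assay on MDA-MB-231 cells (Homo sapiens) for cytotoxicity, read by MTT assay, with a stated time of 72 h (on this read-out higher numbers stand for weaker inhibition and lower numbers for stronger inhibition), gives 840 nM. Compound 2 `C=CCc1cccc(/C=N/NC(=O)Nc2ccc(Oc3ccnc4cc(OCCCN5CCCCC5)c(OC)cc34)c(F)c2)c1OC` gives 790 nM in this assay, and compound 3 `COc1cc2c(Oc3ccc(NC(=O)N/N=C/c4cccs4)cc3F)ccnc2cc1OCCCN1CCCCC1` gives 1260 nM. Compound 3 carries the highest of the three numbers, yet its nearest neighbour is reached by a 1.5-fold higher number from compound 1 to compound 3 (0.18 log units; within the scatter) and the furthest by a 1.6-fold higher number from compound 2 to compound 3 (0.20 log units; within the scatter); together with a 1.1-fold lower number from compound 1 to compound 2 (0.03 log units; within the scatter), every step seen so far lies within the scatter. Compound 4 `COc1cc2c(Oc3ccc(NC(=S)N/N=C/c4ccc(Cl)cc4)cc3F)ccnc2cc1OCCCN1CCCCC1` differs from compound 3 as follows: a group of 12 heavy atoms (8 carbon, 2 nitrogen, 1 sulfur, 1 chlorine; one six-membered aromatic ring of carbon only) in place of a group of 10 heavy atoms (6 carbon, 2 nitrogen, 1 oxygen, 1 sulfur; one five-membered aromatic ring with 1 hetero atom), on a nitrogen on an aromatic ring. Among the measured compounds shown here, the three measured steps all exchange the aromatic group on the carbon with a double bond to nitrogen, and none of them moved the number beyond the scatter; the replacement of the carbonyl by a thiocarbonyl that comes with the entering group has no measured counterpart. No step beyond the scatter is therefore expected for compound 4, the expected step being a 1.3-fold lower number from compound 3 to compound 4 (0.10 log units; within the scatter). Compound 4 is estimated at 1000 nM, within a range from 400 nM to 2500 nM.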

Compound 4, half-maximal inhibitory concentration: 1300 nM
Beside the measured number, compound 4's estimate is 1.3-fold (0.11 log units) below it; low and high end bracket the measured number.
By their numbers in this assay, from the lowest: compounds 2, 1, 3 and 4 (each within the scatter of the next).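

In this assay, the exchange on a nitrogen on an aromatic ring gives a 1.0-fold higher number from compound 3 to compound 4 (0.01 log units; within the scatter). Unlike the earlier steps, which only swapped the aromatic group on the carbon with a double bond to nitrogen, this one also puts a thiocarbonyl in place of the carbonyl and brings in chlorine, and the combined change still stays within the scatter. No supporting measurement bears on this result.

The two parts of the change remain unseparated, so a small net step cannot be assigned to either part, and the thiocarbonyl paired with thiophen-2-yl would be the telling comparison. Also open, as far as these compounds go, is whether an amine or a carboxylic acid on that aromatic group would give a step beyond the scatter.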